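Terminal aryl swap on a growth-inhibition series

The source may report more compounds than this note shows. Statements on the series, on what has been measured and on what is new or still open speak of the compounds shown alone.

Compound 1 `Cc1ccc2[nH]c(-c3ccc(-c4ccc(-c5ccc(N(C)C)cc5)cc4)cc3)nc2c1` gives 8120 nM here
Compound 2 `FC(F)(F)c1ccc(-c2ccc(-c3ccc(-c4nc5ccccc5[nH]4)cc3)cc2)cc1` gives 45200 nM here

In a functional assay on PC-3 cells (Homo sapiens) for inhibition, read by sulforhodamine B assay (a lower number here means a stronger inhibitor of growth, a higher number a weaker inhibitor of growth), compound 2 holds the higher of the two numbers, and compound 1 lies below it by more than the scatter. Compound 3 `Clc1cccc(-c2ccc(-c3ccc(-c4nc5ccccc5[nH]4)cc3)cc2)c1` carries 3-chlorophenyl in place of 4-(trifluoromethyl)phenyl on an aromatic carbon, para to a large group (3-chlorophenyl in place of 4-(trifluoromethyl)phenyl on an aromatic carbon). For the measured compounds named here, no measured step covers this change, so only a small move toward a lower number in this assay is expected, not clearly beyond the scatter. The expected size is a 1.8-fold lower number from compound 2 to compound 3 (0.26 log units; within the scatter) as an estimate only. Compound 3 is estimated at 25000 nM with an expected range from 8000 nM to 70000 nM in this read-out.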

Compound 3, concentration for 50% growth inhibition: 33700 nM
Compound 3: middle estimate off by 1.3-fold (0.13 log units), on the low side, within the range that was stated.
By their numbers in this assay, from the lowest: compound 1; then compounds 3 and 2 (each within the scatter of the next).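

In this assay, for the compounds shown here, 3-chlorophenyl in place of 4-(trifluoromethyl)phenyl gives the first single-place step (a 1.3-fold lower number from compound 2 to compound 3 (0.13 log units; within the scatter)). At this position, then, the exchange of these two aryl groups produces no shift that can be told from the scatter. Nothing at hand explains this result.

As far as these compounds go, whether a carboxylic acid or a primary amine on the terminal ring would move the number beyond the scatter remains open. From the compounds shown here alone, the separate contribution of the methyl on the core of compound 1 also remains open.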